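This account rests on a few compounds, and the source may have more. Where it says the series, first, only, none or still open, it means among the compounds named here.

Measured compounds in the series:

- compound 1 `Cc1ccccc1CNc1nn(-c2ccc(F)cc2F)cc1CNCCN1CCN(C)CC1` — in an ADME assay on Huh-7 cells (Homo sapiens) for cytotoxicity (a lower number here means that less compound is tolerated, a higher number that more compound is tolerated), compound 1 gives > 20000 nM, which is a limit of the assay, not a number.
- compound 2 `Cc1cccc(-c2nn(-c3ccc(F)cc3F)cc2CNCCN2CCN(C)CC2)c1` — in this assay compound 2 gives > 20000 nM, again a limit of the assay.
- compound 3 `Cc1ccccc1-c1nn(-c2ccc(F)cc2F)cc1CNCCN1CCN(C)CC1` — in this assay compound 3 gives > 20000 nM, also a limit of the assay.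

Compound 3 therefore stands only at a limit in this assay, and the same holds for the two other values in the series; all three sit at the limit of > 20000 nM in this assay, at which 3 of the 3 values shown sit. The steps among the measured compounds are accordingly unreadable: a step that the two limits leave unreadable from compound 1 to compound 2, a step that the two limits leave unreadable from compound 1 to compound 3 and a step that the two limits leave unreadable from compound 2 to compound 3.

The unmeasured compound 4 `COc1ccc(-c2nn(-c3ccc(F)cc3F)cc2CNCCN2CCN(C)CC2)cc1` differs from compound 3 by 4-methoxyphenyl in place of 2-methylphenyl on an aromatic carbon. Going by the values given here, no measured step carries a readable size, so none bears on this change beyond showing that all three compounds reach the same limit in this assay. The expectation for the step from compound 3 to compound 4 is therefore no readable shift, a step that the limit leaves unreadable from compound 3 to compound 4, because every value in the series sits at the limit of > 20000 nM in this assay, at which 3 of the 3 values shown sit. Compound 4 is estimated in this assay at 30000 nM, within 10000 nM to 100000 nM, most likely reported again only as a limit.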

Compound 4, half-maximal cytotoxic concentration: > 20000 nM
Compound 4 ended at the assay's limit; the forecaster's own chance of this, stated with the estimate: 85%; the middle value lies beyond the limit too.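

In this assay compound 4 gives > 20000 nM, a limit of the assay. The steps from compound 1, compound 2 and compound 3 to compound 4 cannot be read, with every value at one limit: the limit of > 20000 nM in this assay, at which 4 of the 4 values shown sit. The compounds shown leave open how far each lies past that limit, and whether the groups on this aromatic carbon differ at all in this assay.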